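The source may hold more compounds than are shown below. What is called first, only, known or untested is meant among the compounds shown, and "the series" means these compounds.

Three esters of a shared core have been measured in a functional assay on HEK293 cells for antagonist activity at Voltage-dependent L-type calcium channel subunit alpha-1D (Rattus norvegicus), read by FLIPR; on this read-out higher numbers stand for weaker inhibition and lower numbers for stronger inhibition. Compound 1 `C=C(C)CCOC(=O)C1=C(C)NC(C)=C(C(=O)OC)C1c1cccc([N+](=O)[O-])c1` gives 47 nM, compound 2 `COC(=O)C1=C(C)NC(C)=C(C(=O)OCc2ccc(F)c(F)c2)C1c1cccc([N+](=O)[O-])c1` gives 20 nM, and compound 3 `COC(=O)C1=C(C)NC(C)=C(C(=O)OC2Cc3ccccc3C2)C1c1cccc([N+](=O)[O-])c1` gives 43 nM. Compound 3 thus stands second highest of the three numbers: its nearest neighbour is compound 1, with a 1.1-fold lower number from compound 1 to compound 3 (0.04 log units; within the scatter), and the only gap beyond the scatter is to compound 2, with a 2.2-fold higher number from compound 2 to compound 3 (0.33 log units; beyond the scatter). Compound 4 `COC(=O)C1=C(C)NC(C)=C(C(=O)OCCOCc2ccccc2)C1c1cccc([N+](=O)[O-])c1` keeps the core and alters only the ester group: 2-(benzyloxy)ethyl in place of 2,3-dihydro-1H-inden-2-yl on an oxygen next to a carbonyl group. Every step measured so far touches this same ester group, and none moved the number far: a 2.4-fold lower number from compound 1 to compound 2 (0.37 log units; beyond the scatter), a 1.1-fold lower number from compound 1 to compound 3 (0.04 log units; within the scatter) and a 2.2-fold higher number from compound 2 to compound 3 (0.33 log units; beyond the scatter). A benzyl group already appears in compound 2, but the 2-(benzyloxy)ethyl chain of compound 4 is unlike any ester side measured so far, and nothing measured bears on it directly. The step this estimate means, a 1.1-fold lower number from compound 3 to compound 4 (0.03 log units; within the scatter), is expected to stay within the scatter. The estimate for compound 4 in this assay is 40 nM, with a range from 15 nM to 110 nM.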

Compound 4, half-maximal inhibitory concentration: 12 nM
Compound 4: middle estimate off by 3.3-fold (0.52 log units), on the high side, and the stated range ends above it.
By their numbers in this assay, from the lowest: compounds 4 and 2 (each within the scatter of the next); then compounds 3 and 1 (each within the scatter of the next).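

In this assay, the steps of a 3.6-fold lower number from compound 3 to compound 4 (0.55 log units; beyond the scatter) and a 3.9-fold lower number from compound 1 to compound 4 (0.59 log units; beyond the scatter) are larger than any step among the earlier compounds, so this ester position can move the number further than they had shown. The step of a 1.7-fold lower number from compound 2 to compound 4 (0.22 log units; within the scatter) leaves the 2-(benzyloxy)ethyl group of compound 4 level with the 3,4-difluorobenzyl group of compound 2, so two differently built groups on this oxygen give numbers within the scatter, while compound 3, which also carries a six-membered aromatic ring, does not join them. Nothing available explains these differences.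

On these data alone, whether a 4-phenylbutyl ester, with carbon in place of the chain oxygen, would read like compound 4 stays open. So does the effect of an amine in that chain, or of a longer chain.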